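Pyrrolidine to fused bicyclic amine on two related cores

A few compounds are considered here, and "the series" means these few. Any claim that something is new, unique, unknown or untested is made for them only; others in the source may bear on it.

Compound 1 `COc1ncc(-c2cc3c(N4CCCC4)ncnc3s2)cc1NS(=O)(=O)c1ccc(F)cc1F` and compound 2 `COc1ncc(-c2cc3c(N4CC5CCCC5C4)ncnc3s2)cc1NS(=O)(=O)c1ccc(F)cc1F` share one core; compound 3 `COc1ncc(-c2nc3c(N4CCCC4)ncnc3s2)cc1NS(=O)(=O)c1ccc(F)cc1F` and compound 4 `COc1ncc(-c2nc3c(N4CC5CCCC5C4)ncnc3s2)cc1NS(=O)(=O)c1ccc(F)cc1F` share another. How the two cores differ is not broken down here. In a functional assay on HGC-27 cells (Homo sapiens) for antiproliferative activity, read by MTT assay, with stated times of 72 h and 4 h (a higher number here means a weaker inhibitor, a lower number a stronger inhibitor), compound 1 gives 2300 nM and compound 2 gives 1900 nM. The change between them is a group of 8 heavy atoms (7 carbon, 1 nitrogen; one five-membered non-aromatic ring of carbon only, one five-membered non-aromatic ring with 1 hetero atom) in place of a group of 5 heavy atoms (4 carbon, 1 nitrogen; one five-membered non-aromatic ring with 1 hetero atom), on an aromatic carbon and it gave a 1.2-fold lower number from compound 1 to compound 2 (0.08 log units; within the scatter). In this assay compound 3 gives 1200 nM; its values against compound 2 and compound 1 lie within the scatter, so no order among the three is claimed. Compound 4 is not yet measured in this assay. It carries the same change as compound 2, namely (a group of 8 heavy atoms (7 carbon, 1 nitrogen; one five-membered non-aromatic ring of carbon only, one five-membered non-aromatic ring with 1 hetero atom) in place of a group of 5 heavy atoms (4 carbon, 1 nitrogen; one five-membered non-aromatic ring with 1 hetero atom), on an aromatic carbon), applied to the core of compound 3. The expectation rests on compound 1 to compound 2, where the step was a 1.2-fold lower number from compound 1 to compound 2 (0.08 log units; within the scatter), and on the value of compound 3, 1200 nM. The step from compound 3 to compound 4 in this assay is therefore expected to be small, about a 1.2-fold lower number from compound 3 to compound 4 (0.08 log units; within the scatter). Compound 4 is estimated at 1000 nM, with a likely range from 400 nM to 2500 nM, on one prior example only.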

Compound 4, half-maximal inhibitory concentration: 310 nM
For compound 4 the middle estimate is 3.2-fold (0.51 log units) above the measured one; measured number below the stated range.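

In this assay, exchanging pyrrolidin-1-yl for the fused bicyclic amine on the core of compound 3 gave a 3.9-fold lower number from compound 3 to compound 4 (0.59 log units; beyond the scatter), a step clearly larger than the scatter. Set beside the earlier step, the change does not carry over with a constant size from one core to the other: the same change on two cores in this assay, a 1.2-fold lower number (0.08 log units; within the scatter) from compound 1 to compound 2 and a 3.9-fold lower number (0.59 log units; beyond the scatter) from compound 3 to compound 4, 3.2-fold (0.50 log units) apart, beyond the scatter of two such steps. Among the compounds shown here, with only one pair on each core, this shows that the size of the step depended on the core in these two examples, but it does not show which difference between the cores is responsible or what the step would be on any further core.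

The compounds shown leave open whether the larger step on the core of compound 3 is particular to this fused bicyclic amine or would also appear with a simpler amine on the same aromatic carbon, such as piperidine or morpholine. Also open, going by these compounds, is whether the dependence on the core would persist with a methyl sulfonamide in place of the fluorinated aryl sulfonamide.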